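Benzylsulfanyl Removal on Two Related Cores in KB Cells

The source may hold more compounds than are shown below. What is called first, only, known or untested is meant among the compounds shown, and "the series" means these compounds.

Compound 1 `OCCOCn1c(SCc2ccccc2)nc2c(Cl)cc(Cl)cc21` and compound 2 `OCCOCn1cnc2c(Cl)cc(Cl)cc21` share one core, while compound 3 `OCCOCn1c(SCc2ccccc2)nc2c(Cl)c(Cl)ccc21` and compound 4 `OCCOCn1cnc2c(Cl)c(Cl)ccc21` share another; the difference between the two cores is not broken down here. In a functional assay on KB cells (Homo sapiens) for inhibition (a higher number here means a weaker inhibitor, a lower number a stronger inhibitor), compound 1 reaches only the limit > 100000 nM. Compound 2 likewise gives only the limit > 100000 nM in this assay. Compound 3 gives 35000 nM in this assay. The change from compound 1 to compound 2, (hydrogen in place of benzylsulfanyl on an aromatic carbon), gives a step that the two limits leave unreadable from compound 1 to compound 2, as shown by the limit of > 100000 nM in this assay, at which 2 of the 3 values shown sit. The same change, (hydrogen in place of benzylsulfanyl on an aromatic carbon), is made from compound 3 to compound 4. Because compound 3 already gives 35000 nM, a step of a 4.3-fold higher number from compound 3 to compound 4 (0.63 log units; beyond the scatter) is expected. Compound 4 is therefore estimated at 150000 nM, within 30000 nM to 600000 nM.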

Compound 4, half-maximal inhibitory concentration: > 100000 nM
Compound 4: no number, only a limit; the forecaster's own chance of this, stated with the estimate: 70%; the middle value does not contradict the limit.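

Replacing benzylsulfanyl with hydrogen gives an at least 2.8-fold higher number from compound 3 to compound 4 (0.45 log units; beyond the scatter) in this assay, so on the core of compound 3 the removal weakens inhibition. Compound 4 reaches only the limit > 100000 nM, which is a limit and not a number. The same change on the core of compound 1 cannot be read, so the data do not show whether the step carries over from one core to the other, nor how large the step on the core of compound 3 really is, because most values here are limits: the limit of > 100000 nM in this assay, at which 3 of the 4 values shown sit.

The compounds shown leave open whether another group in place of benzylsulfanyl, such as an amine or methylsulfanyl, would keep the inhibition seen with compound 3. They also leave open whether such a group would give a readable number on the core of compound 1.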